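The source may hold more compounds than are shown below. What is called first, only, known or untested is meant among the compounds shown, and "the series" means these compounds.

Compound 1: `Nc1cc(-c2ccccc2)ccc1Cn1cncc1CNc1ccc(Cl)c(-c2ccccc2)c1`, giving > 1000 nM in a toxicity assay on NIH3T3 cells (Mus musculus) for cytotoxicity, read by resazurin assay; a higher number here means that more compound is needed for the effect, a lower number that less compound is needed
Compound 2: `CC(C)c1ccc(Cn2cncc2CNc2ccc(-c3nc4ccccc4s3)c(-c3ccccc3)c2)cc1`, giving > 1000 nM in this assay
Compound 3: `COC(=O)c1ccc(NCc2cncn2Cc2ccc(N)cc2)cc1-c1ccccc1`, giving > 10000 nM in this assay

Every value here is a limit of this assay rather than a number. For compound 1 the reading is the limit > 1000 nM. For compound 2 the reading is the same kind of limit, > 1000 nM. Compound 3 stands apart only in that its limit, > 10000 nM, was set higher: it sits at the limit of > 10000 nM in this assay, at which 1 of the 3 values shown sits, whereas the other two sit at the limit of > 1000 nM in this assay, at which 2 of the 3 values shown sit. None of the three shows measurable cytotoxicity.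

Compound 4, `COC(=O)c1ccc(NCc2cncn2Cc2cccc(Cl)c2)cc1-c1ccccc1`, differs from compound 3 by a single change: 3-chlorophenyl in place of 4-aminophenyl on a saturated chain carbon bound to an aromatic nitrogen. For the measured compounds named here, no step between two measured compounds covers this change, so the expectation rests on compound 3 alone. Given that compound 3 reached only the limit > 10000 nM, compound 4 is expected to behave likewise, with an expected step that the limit leaves unreadable from compound 3 to compound 4 that is none beyond the usual scatter. Compound 4 is therefore estimated at 15000 nM, within 4000 nM to 50000 nM, most likely reported again as a limit.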

Compound 4, half-maximal effective concentration: > 10000 nM
Compound 4: a limit, no number (the forecaster's own chance of this, stated with the estimate: 85%); the middle value does not contradict the limit.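

Compound 3 gives > 10000 nM in this assay, a limit and not a number. Compound 4 gives > 10000 nM, again a limit. For the compounds shown here, no step can therefore be read between compound 3 and compound 4. The compounds shown leave open at what concentration, if any, cytotoxicity would appear.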